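This account rests on a few compounds, and the source may have more. Where it says the series, first, only, none or still open, it means among the compounds named here.

The series shares one core carrying an acid and a nitrogen substituent on the aromatic ring; the nitrogen substituent is what varies. Compound 1 `CNC(=O)Nc1c(C)c(C(OC(C)(C)C)C(=O)O)c(-c2ccc(C)c(C)c2)c(C)c1-c1ccc(C)c(C)c1` bears a methylcarbamoyl on that nitrogen and in an ADME assay on MT4 cells (Homo sapiens) for cytotoxicity, read by MTT assay, with a stated time of 4 days (a lower number here means that less compound is tolerated, a higher number that more compound is tolerated), compound 1 gives 20000 nM. Compound 2 `CC(=O)Nc1c(C)c(C(OC(C)(C)C)C(=O)O)c(-c2ccc(C)c(C)c2)c(C)c1-c1ccc(C)c(C)c1` carries an acetyl instead, and in this assay compound 2 gives 19000 nM. Compound 3 `Cc1ccc(-c2c(C)c(-c3ccc(C)c(C)c3)c(C(OC(C)(C)C)C(=O)O)c(C)c2NS(=O)(=O)C2CC2)cc1C` carries a cyclopropylsulfonyl, and in this assay compound 3 gives 11000 nM, a number that differs from those of compound 2 and compound 1 only within the scatter, as the steps of a 1.8-fold lower number from compound 1 to compound 3 (0.26 log units; within the scatter) and a 1.7-fold lower number from compound 2 to compound 3 (0.24 log units; within the scatter) show; likewise a 1.1-fold lower number from compound 1 to compound 2 (0.02 log units; within the scatter) is flat.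

Compound 4 `CNc1c(C)c(C(OC(C)(C)C)C(=O)O)c(-c2ccc(C)c(C)c2)c(C)c1-c1ccc(C)c(C)c1` is the next step: methyl in place of cyclopropylsulfonyl on a nitrogen on an aromatic ring. Among the measured compounds shown here, the steps that bear on it are the three exchanges on the same nitrogen, all within the scatter. Methyl has no measured counterpart here, but every change at this nitrogen so far left this assay unmoved, so no step beyond the scatter is expected, a 1.4-fold higher number from compound 3 to compound 4 (0.13 log units; within the scatter). Compound 4 is estimated at 15000 nM, with a range of 6000 nM to 40000 nM.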

Compound 4, half-maximal cytotoxic concentration: 8800 nM
The estimate for compound 4 lay 1.7-fold (0.23 log units) above the measured number; the measured number falls inside the stated range.
By their numbers in this assay, from the lowest: compounds 4, 3, 2 and 1 (each within the scatter of the next, the first and the last beyond it).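

In this assay this nitrogen gives its first steps beyond the scatter with methyl, at a 2.2-fold lower number from compound 2 to compound 4 (0.33 log units; beyond the scatter) on leaving acetyl and a 2.3-fold lower number from compound 1 to compound 4 (0.36 log units; beyond the scatter) on leaving methylcarbamoyl; both steps are modest. The exchange from cyclopropylsulfonyl stays within the scatter at a 1.3-fold lower number from compound 3 to compound 4 (0.10 log units; within the scatter) and so the position is no longer wholly flat: methyl separates from the two carbonyl-bearing groups but not from the sulfonyl group. No data given here account for these steps.

Still open, from the compounds shown here alone, is whether an unsubstituted amine, a longer chain such as propyl or a carboxylic acid on this nitrogen would fall with methyl or with acetyl and methylcarbamoyl. Also open, going by these compounds, is whether the same modest steps would hold if the acid side of the shared core were changed.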